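This account rests on a few compounds, and the source may have more. Where it says the series, first, only, none or still open, it means among the compounds named here.

Measured so far: compound 1 `CCCCNc1nc(N)nc2c1CCN(Cc1ccccc1)C2` gives 0.4 uM; compound 2 `CCCCNc1nc(N)nc2c1CNCC2` gives 7.2 uM; compound 3 `CCCCNc1nc(N)nc2c1CCN(C)C2` gives 0.2 uM.

On an assay on HEK293 cells for agonist activity at Toll-like receptor 8 (Homo sapiens), read by a luciferase reporter, with a stated time of 6 h (on this read-out higher numbers stand for an effect only at larger amounts of compound and lower numbers for an effect already at smaller amounts), compound 2 stands highest of the three; compound 1 at 0.4 uM and compound 3 at 0.2 uM both lie beyond the scatter from it. Among the compounds with values here, the only step between measured compounds, a 2.0-fold lower number from compound 1 to compound 3 (0.30 log units; within the scatter), is within the scatter. Compound 4 `CCCCNc1nc(N)nc2c1CN(C(C)=O)CC2` differs from compound 2 by acetyl in place of hydrogen on an amine nitrogen in a ring. Within the data shown here, no measured step involves an acetyl; compounds 1 and 3 show only that a substituent on the same ring nitrogen goes with a lower number than the hydrogen of compound 2, and an acetyl is not such a saturated chain. For compound 4 a moderate lowering is expected, a 2.4-fold lower number from compound 2 to compound 4 (0.38 log units; beyond the scatter), with wide uncertainty. Compound 4 is estimated at 3 uM, between 0.5 uM and 15 uM.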

Compound 4, minimum effective concentration: 0.5 uM
For compound 4 the middle estimate is 6.0-fold (0.78 log units) above the measured one; the measured number falls inside the stated range.
By their numbers in this assay, from the lowest: compounds 3, 1 and 4 (each within the scatter of the next, the first and the last beyond it); then compound 2.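

In this assay, acetyl in place of hydrogen on an amine nitrogen in a ring gives a 14-fold lower number from compound 2 to compound 4 (1.16 log units; beyond the scatter), so this free ring hydrogen is not required for an effect at smaller amounts of compound. Within the data shown here, this is the first step that reaches beyond the scatter and the only one at this nitrogen, so it shows that this position can change the read-out substantially. Nothing available explains the size of this step.

As far as these compounds go, whether the carbonyl matters here, or whether any group on this nitrogen goes with a lower number, remains open. An ethyl or a longer acyl such as butanoyl at this nitrogen would separate those readings.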